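Extending a side chain on a quinoline-triazole core

The source may hold more compounds than are shown below. What is called first, only, known or untested is meant among the compounds shown, and "the series" means these compounds.

A small set of quinoline-linked triazoles was examined in a functional assay on U-937 cells (Homo sapiens) for cytotoxicity, read by MTT assay, with a stated time of 24 h; on this read-out higher numbers stand for weaker inhibition and lower numbers for stronger inhibition. Compound 1 `CCCCCCCCCCn1cc(-c2nc3ccccc3cc2CCCC)nn1` gave 25.2 ug/mL in this assay, and compound 2 `CCCCCCCCCCn1cc(-c2nc3ccccc3cc2CCC)nn1` gave 26.6 ug/mL. The two differ only by the change (methyl in place of hydrogen on a saturated chain carbon, three bonds along the chain from an aromatic carbon), and that step, a 1.1-fold lower number from compound 2 to compound 1 (0.02 log units; within the scatter), made almost no difference to the read-out. Compound 3 `CCCc1cc2ccccc2nc1-c1cn(-c2ccc(F)cc2)nn1` carries a different group on the triazole and gave 67.4 ug/mL, the highest number of the three measured; the difference between its core and that of compound 2 is not broken down here.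

Compound 4 `CCCCc1cc2ccccc2nc1-c1cn(-c2ccc(F)cc2)nn1` has not yet been measured. It differs from compound 3 by methyl in place of hydrogen on a saturated chain carbon, three bonds along the chain from an aromatic carbon, the same kind of change that separates compound 2 from compound 1, made at the same place. Since that earlier step, a 1.1-fold lower number from compound 2 to compound 1 (0.02 log units; within the scatter), stayed within the usual scatter, the step from compound 3 to compound 4 is expected to be of similar size, about a 1.1-fold lower number from compound 3 to compound 4 (0.04 log units; within the scatter). On that basis compound 4 is estimated to give 62 ug/mL in this assay, with a plausible range from 35 ug/mL to 110 ug/mL.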

Compound 4, half-maximal inhibitory concentration: 66.2 ug/mL
Compound 4: the middle estimate sits 1.1-fold (0.03 log units) below what was measured; low and high end bracket the measured number.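

In this assay, the same methyl-for-hydrogen change, which takes propyl to butyl, gave a 1.0-fold lower number from compound 3 to compound 4 (0.01 log units; within the scatter) on the core of compound 3, so the read-out again stayed within the usual scatter. Among the compounds shown here, the change therefore carried from the core of compound 1 to the core of compound 3 with no difference that can be told apart: the same change on two cores in this assay, a 1.1-fold lower number (0.02 log units; within the scatter) from compound 2 to compound 1 and a 1.0-fold lower number (0.01 log units; within the scatter) from compound 3 to compound 4, 1.0-fold (0.02 log units) apart, within the scatter of two such steps This shows only that the step has no measurable size on these two cores in this one assay; since neither step stands out from the scatter, the agreement is between two null results and does not show that a change with a real effect would carry over in the same way.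

The compounds shown leave open whether a longer chain than butyl, or an amine or a carboxylic acid at the end of the chain, would move the number on either core. They also leave open whether the step would stay this small with another group on the triazole, such as a benzyl.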